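The compounds below may be only part of what the source reports. "The series", "measured", "known", "first", "only" and "open" are said of these compounds alone.

Compound 1 `O=C(Oc1ccc(Br)cc1C(=O)Nc1ccc(C(F)(F)F)cc1)c1ccc(Br)cc1` sits in an ADME assay on HepG2 cells (Homo sapiens) for cytotoxicity, read by MTT assay, with a stated time of 72 h (a lower number here means a stronger inhibitor, a higher number a weaker inhibitor), at a limit, > 50000 nM, and carries no number of its own. Compound 2 `O=C(Oc1ccc(Cl)cc1C(=O)Nc1ccc(Cl)c(Cl)c1)c1ccc(Br)cc1` reaches the same kind of limit, > 50000 nM. Compound 3 `Cc1ccc(C(=O)Oc2ccc(Cl)cc2C(=O)Nc2ccc(Cl)c(Cl)c2)cc1` likewise shows only a limit, > 50000 nM. Going by the values given here, the single measured step, a step that the two limits leave unreadable from compound 2 to compound 3, is therefore unreadable, and with the limit of > 50000 nM in this assay, at which 3 of the 3 values shown sit, no step can be sized at all. Compound 4 `O=C(Oc1ccc(Br)cc1C(=O)Nc1ccc(C(F)(F)F)cc1)c1ccc([N+](=O)[O-])cc1` differs from compound 1 by nitro in place of bromo on an aromatic carbon. Among the compounds with values here, no measured step concerns a nitro group, so the change has no precedent in these data. Within the data shown here, since every value so far is a limit, compound 4 is expected to return a limit as well. The step that the limit leaves unreadable from compound 1 to compound 4 is expected to show no readable change. The estimate for compound 4 is 60000 nM, within 20000 nM to 200000 nM.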

Compound 4, half-maximal inhibitory concentration: > 50000 nM
Compound 4 ended at the assay's limit; the forecaster's own chance of this, stated with the estimate: 85%; the middle value lies beyond the limit too.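

No new step can be read between compound 1 and compound 4 in this assay, since both values are limits: the limit of > 50000 nM in this assay, at which 4 of the 4 values shown sit.

The compounds shown leave open whether any change to the shared core gives a value inside the assay's range.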